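Moving the Chlorine Around the Pyridine Amide

The source may hold more compounds than are shown below. What is called first, only, known or untested is meant among the compounds shown, and "the series" means these compounds.

Compound 2 `Cn1cc(-c2cnc(N)c(Oc3ccc(C(=O)Nc4cccc(Cl)n4)cc3)n2)cn1` carries a 6-chloropyridin-2-yl on an amide-type nitrogen, and in a functional assay on HepG2 cells (Homo sapiens) for inhibition, read by MTT assay, with a stated time of 72 h (a lower number here means a stronger inhibitor, a higher number a weaker inhibitor), compound 2 gives 44200 nM. Compound 1 `Cn1cc(-c2cnc(N)c(Oc3ccc(C(=O)Nc4ccccc4Cl)cc3)n2)cn1` bears a 2-chlorophenyl in the same place; in this assay compound 1 gives 66900 nM. The step of a 1.5-fold lower number from compound 1 to compound 2 (0.18 log units; within the scatter) lies within the scatter, so the two numbers cannot be told apart. Compound 3 `Cn1cc(-c2cnc(N)c(Oc3ccc(C(=O)Nc4cc(Cl)ccn4)cc3)n2)cn1` differs from compound 2 by 4-chloropyridin-2-yl in place of 6-chloropyridin-2-yl on an amide-type nitrogen. For the measured compounds named here, only that one measured step bears on this change, and it was within the scatter, so no shift beyond the scatter is expected; the expected step is a 1.1-fold lower number from compound 2 to compound 3 (0.02 log units; within the scatter). Compound 3 is estimated at 42000 nM, within a range from 18000 nM to 95000 nM.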

Compound 3, half-maximal inhibitory concentration: > 100000 nM
Compound 3 was reported as a limit; the forecaster's own chance of this, stated with the estimate: 10%; middle value at least 2.3-fold (0.37 log units) away from the limit.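

Compound 3 is reported only as a limit in this assay, not as a number: the limit of > 100000 nM in this assay, at which 1 of the 3 values shown sits.

Even so, the position of the chlorine on the pyridine matters here, which the earlier pair could not show: swapping 6-chloropyridin-2-yl for 4-chloropyridin-2-yl gives an at least 2.2-fold higher number from compound 2 to compound 3 (0.35 log units; beyond the scatter). Against the 2-chlorophenyl the result is an at least 1.4-fold higher number from compound 1 to compound 3 (0.17 log units; that floor lies within the scatter), so that comparison stays unsettled.

The compounds shown leave open how a methoxy group or an amine in place of the chlorine would read. They also leave open whether any group on this amide-type nitrogen could give a much lower number.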